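The source may report more compounds than this note shows. Statements on the series, on what has been measured and on what is new or still open speak of the compounds shown alone.

Two compounds have been measured in a functional assay on UACC-257 cells (Homo sapiens) for inhibition; a higher number here means a weaker inhibitor of growth, a lower number a stronger inhibitor of growth:

Compound 1, `COc1cc(/C=C/C(=O)c2cccc(-n3cc(-c4ccccc4)[nH]c3=O)c2)ccc1O`, gives 6810 nM.
Compound 2, `COc1cc(/C=C/C(=O)c2cccc(-n3cc(-c4ccccc4)[nH]c3=O)c2)cc(OC)c1OC`, gives 1520 nM.

Compound 2 holds the lowest of the two numbers in this assay, with compound 1 at a higher number, a gap beyond the scatter. Compound 3, `COc1ccc(-c2cn(-c3cccc(C(=O)/C=C/c4cc(OC)c(OC)c(OC)c4)c3)c(=O)[nH]2)cc1`, differs from compound 2 by methoxy in place of hydrogen on an aromatic carbon, a methoxy in place of hydrogen on an aromatic carbon. For the measured compounds named here, no measured pair shows this change, so its size cannot be read from these data. A small step is expected, a 1.0-fold lower number from compound 2 to compound 3 (0.01 log units; within the scatter), in either direction or none beyond the scatter. Compound 3 is therefore estimated at 1500 nM, within 500 nM to 4500 nM.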

Compound 3, concentration for 50% growth inhibition: 3040 nM
Estimate against measurement, compound 3: 2.0-fold (0.31 log units) below; the measured number falls inside the stated range.
By their numbers in this assay, from the lowest: compounds 2 and 3 (each within the scatter of the next); then compound 1.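

For the compounds shown here, the change from phenyl to 4-methoxyphenyl gives a 2.0-fold higher number from compound 2 to compound 3 (0.30 log units; within the scatter) in this assay, the first reading of any substitution at this position. On the background of compound 2, this aromatic carbon therefore takes a methoxy with no change beyond the scatter, though this rests on a single pair. Nothing available here explains the result.

On these data alone, whether a larger group such as butoxy, or an amine or a carboxylic acid, would be taken up as well at this position remains open. Also open, as far as these compounds go, is whether the same methoxy step would hold on the core of compound 1.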